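The compounds below may be only part of what the source reports. "The series", "measured", "known", "first", "only" and "open" are said of these compounds alone.

Three measured compounds share a common framework and were examined in a functional assay on A549 cells (Homo sapiens) for antiproliferative activity, read by MTT assay, with a stated time of 48 h; on this read-out lower numbers stand for stronger inhibition and higher numbers for weaker inhibition. Compound 2 `Cc1ccc2nc(NC(c3cn(-c4ccccc4)nc3-c3cccc(Cl)c3)c3c(O)ccc4ccccc34)sc2c1` gives 45400 nM. Compound 1 `Cc1ccc2nc(NC(c3cn(-c4ccccc4)nc3-c3cccc([N+](=O)[O-])c3)c3c(O)ccc4ccccc34)sc2c1` differs from it by nitro in place of chloro on an aromatic carbon; in this assay compound 1 gives 57400 nM, and the step is a 1.3-fold higher number from compound 2 to compound 1 (0.10 log units; within the scatter). Compound 3 `COc1ccc2nc(NC(c3cn(-c4ccccc4)nc3-c3ccc(Cl)cc3)c3c(O)ccc4ccccc34)sc2c1` gives 34500 nM in this assay; the difference between its core and the core of compound 2 is not broken down here, and the numbers of compound 3 and compound 2 lie within the scatter of each other. Compound 4 `COc1ccc2nc(NC(c3cn(-c4ccccc4)nc3-c3ccc([N+](=O)[O-])cc3)c3c(O)ccc4ccccc34)sc2c1` has not yet been measured. It differs from compound 3 by nitro in place of chloro on an aromatic carbon. This is the same kind of change as that between compound 2 and compound 1, but the place differs: meta to a large group in the earlier pair, para to a large group in the present one. Because the earlier step of a 1.3-fold higher number from compound 2 to compound 1 (0.10 log units; within the scatter) stayed within the scatter, the step from compound 3 to compound 4 is expected to be of similar size, a 1.3-fold higher number from compound 3 to compound 4 (0.12 log units; within the scatter). Compound 4 is therefore estimated at 45000 nM, with a likely range from 25000 nM to 80000 nM.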

Compound 4, half-maximal inhibitory concentration: 22500 nM
The estimate for compound 4 lay 2.0-fold (0.30 log units) above the measured number; measured number outside the range, below it.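

In this assay, the new pair gives a 1.5-fold lower number from compound 3 to compound 4 (0.19 log units; within the scatter). Set beside the earlier pair, the change from chloro to nitro does not separate the two cores: the same change on two cores in this assay, a 1.3-fold higher number (0.10 log units; within the scatter) from compound 2 to compound 1 and a 1.5-fold lower number (0.19 log units; within the scatter) from compound 3 to compound 4, 1.9-fold (0.29 log units) apart, within the scatter of two such steps. On both cores the change left the number within the scatter, and no dependence on the core can be read from these pairs, but this does not show that the change is without effect elsewhere in the series, as it rests on two pairs only, which differ in the place of the group as well as in the core.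

The compounds shown carry only chloro and nitro in this place on the aromatic ring, all with numbers in the same narrow band, so they give no view of a step beyond the scatter. As far as these compounds go, whether an amine or a carboxylic acid in that place would move the number beyond the scatter remains open, as does whether the chloro-to-nitro result holds on other cell lines.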